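This account rests on a few compounds, and the source may have more. Where it says the series, first, only, none or still open, it means among the compounds named here.

Measured so far in a functional assay on HCT-116 cells (Homo sapiens) for inhibition, read by CCK-8 assay, with a stated time of 48 h; a lower number here means a stronger inhibitor, a higher number a weaker inhibitor:
compound 1 `COc1cc(-c2ccnc3cc(-c4ccc(C)cc4)nn23)cc(OC)c1OC` gives 48 nM
compound 2 `C=Cc1ccc(-c2cc3nccc(-c4cc(OC)c(OC)c(OC)c4)n3n2)cc1` gives 1060 nM
compound 3 `COc1cc(-c2ccnc3cc(-c4cccc(C)c4)nn23)cc(OC)c1OC` gives 6150 nM

Compound 3 has the highest number of the three and is the weakest inhibitor here, with its steps to both others beyond the scatter.

Compound 4 `COc1ccc(-c2cc3nccc(-c4cc(OC)c(OC)c(OC)c4)n3n2)cc1` carries 4-methoxyphenyl in place of 3-methylphenyl on an aromatic carbon. Two measured steps make the same exchange of the 3-methylphenyl group for another 4-substituted phenyl, seen in reverse. With 4-methylphenyl the gap is large, at a 130-fold higher number from compound 1 to compound 3 (2.11 log units; beyond the scatter), and with 4-vinylphenyl it is modest, at a 5.8-fold higher number from compound 2 to compound 3 (0.76 log units; beyond the scatter). These two compounds also differ widely from each other, at a 22-fold higher number from compound 1 to compound 2 (1.34 log units; beyond the scatter), so the size of the next step is uncertain.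

A lower number is expected in this assay, a modest to large step, estimated as a 21-fold lower number from compound 3 to compound 4 (1.31 log units; beyond the scatter). Compound 4 is expected at 300 nM, with an estimated range from 50 nM to 2000 nM.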

Compound 4, half-maximal inhibitory concentration: 404 nM
Beside the measured number, compound 4's estimate is 1.3-fold (0.13 log units) below it; low and high end bracket the measured number.
By their numbers in this assay, from the lowest: compound 1; then compound 4; then compound 2; then compound 3.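

With 4-methoxyphenyl in place of 3-methylphenyl on the aromatic carbon next to the ring nitrogen, the number falls again in this assay (a 15-fold lower number from compound 3 to compound 4 (1.18 log units; beyond the scatter)), so all three 4-substituted phenyl compounds now lie below compound 3, and none of those shown goes against this. The group at the 4-position also orders the series, with methoxy lying between the other two: vinyl gives way to methoxy with a lower number (a 2.6-fold lower number from compound 2 to compound 4 (0.42 log units; beyond the scatter)), while methoxy in place of methyl gives a higher one (an 8.4-fold higher number from compound 1 to compound 4 (0.93 log units; beyond the scatter)). No measured evidence here accounts for these differences.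

The 3-substituted side rests on compound 3 alone, so 3-methoxyphenyl would show whether its high number holds beyond the 3-methylphenyl group. On these data alone, it also remains open how far the 4-position tolerates change, for example with 4-ethylphenyl or with an amine such as 4-dimethylaminophenyl.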